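A few compounds are considered here, and "the series" means these few. Any claim that something is new, unique, unknown or untested is made for them only; others in the source may bear on it.

Compounds measured in a functional assay on HeLa cells (Homo sapiens) for inhibition, read by sulforhodamine B assay, with a stated time of 48 h; a higher number here means a weaker inhibitor of growth, a lower number a stronger inhibitor of growth:

- compound 1, `CC(=O)OC/C(=C\C1CCCCC1)C(=O)c1ccccc1`, 21000 nM
- compound 2, `CC(=O)OC/C(=C\c1ccc(F)cc1)C(=O)c1ccccc1`, 25000 nM
- compound 3, `CC(=O)OC/C(=C\c1ccccc1Br)C(=O)c1ccccc1`, 20000 nM

Compound 3 has the lowest number of the three, but its neighbours sit close: the step of a 1.1-fold lower number from compound 1 to compound 3 (0.02 log units; within the scatter) and the step of a 1.3-fold lower number from compound 2 to compound 3 (0.10 log units; within the scatter) are both inside the scatter, so no order among compounds 1, 2 and 3 can be read from these numbers. The step of a 1.2-fold higher number from compound 1 to compound 2 (0.08 log units; within the scatter) is likewise inside the scatter.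

Compound 4, `CC(=O)OC/C(=C/c1ccccc1Br)C(=O)c1ccccc1`, is the geometric partner of compound 3: the two compounds have the same atoms and bonds and differ only in configuration as drawn: 1 of 1 stereo elements differ; a double bond is drawn E in compound 3 and Z in compound 4. None of the three measured steps bears on this change; each of them swaps the group on the double-bonded chain carbon and leaves the configuration as it stands, and all three steps were within the scatter. There is therefore no measured guide to how the drawn geometry moves the number in this assay, and the default expectation is a step of no more than the scatter in either direction. The step of a 1.1-fold higher number from compound 3 to compound 4 (0.04 log units; within the scatter) is the expected change. Compound 4 is expected to give about 22000 nM in this assay, with a range of 8000 nM to 60000 nM.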

Compound 4, concentration for 50% growth inhibition: 19000 nM
For compound 4 the middle estimate is 1.2-fold (0.06 log units) above the measured one; measured number inside the range.
By their numbers in this assay, from the lowest: compounds 4, 3, 1 and 2 (each within the scatter of the next).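

Among these compounds, the step in this assay, a 1.1-fold lower number from compound 3 to compound 4 (0.02 log units; within the scatter), gives the first reading of the drawn geometry at this double bond, whereas the earlier steps only swapped the group on the double-bonded chain carbon and left the configuration as it stood. With the 2-bromophenyl group in place, the E and Z forms cannot be told apart by their numbers in this assay, so within this pair the drawn geometry shows no measurable effect on growth inhibition. The comparison speaks to configuration and to nothing else, and no change of group enters into it, because the pair shares all its atoms and bonds: the fact that compounds 3 and 4 differ only in the configuration as drawn.

On these data alone, whether the geometry counts for as little with the cyclohexyl group of compound 1 or the 4-fluorophenyl group of compound 2 remains open, as this single pair speaks only for the 2-bromophenyl group. Also open, as far as these compounds go, is whether a quite different group on the double-bonded chain carbon, such as an amine or a carboxylic acid, would give a step beyond the scatter in this assay.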